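The compounds below may be only part of what the source reports. "The series", "measured", "known", "first", "only" and "open" are said of these compounds alone.

Among the compounds with values here, compound 1 `CCC(C)C1NC(=O)N(C2CCCC2)C1=O` was tested in a functional assay on MCF7 cells (Homo sapiens) for inhibition (on this read-out higher numbers stand for weaker inhibition and lower numbers for stronger inhibition), and in this assay compound 1 gives 67400 nM, the only number recorded in the set. Compound 2 `CCC(C)C(NC(=O)NO)C(=O)NCc1ccccc1` belongs to the same series. For compound 2 the read-out in this assay is a limit rather than a number, > 100000 nM, and so compound 2 sits at the limit of > 100000 nM in this assay, at which 1 of the 2 values shown sits. Compound 1 thus stands as the single measured point from which the next step is taken. Compound 3 `CC(C)C1NC(=O)N(C2CCCC2)C1=O` differs from compound 1 by hydrogen in place of methyl on a saturated chain carbon, two bonds along the chain from a saturated ring carbon. With no measured step of this kind in the set, the expectation for the step from compound 1 to compound 3 is a small shift, a 1.3-fold higher number from compound 1 to compound 3 (0.13 log units; within the scatter), toward weaker inhibition or none beyond the usual scatter. Compound 3 is therefore expected to give 90000 nM in this assay, within a range from 35000 nM to 250000 nM.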

Compound 3, half-maximal inhibitory concentration: > 100000 nM
Compound 3: a limit, no number; the forecaster's own chance of this, stated with the estimate: 35%; at least 1.1-fold (0.04 log units) between middle value and limit.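

In this assay the change from sec-butyl to isopropyl, the only step at this position among the compounds shown, reads as an at least 1.4-fold higher number from compound 1 to compound 3 (0.17 log units; that floor lies within the scatter) and gives the position its first comparison. Compound 3 gives a limit and not a number, so the step has a floor but no size, and it does not show that removing the methyl separates the two compounds beyond the usual scatter. The values at this end of the read-out now gather at one limit: the limit of > 100000 nM in this assay, at which 2 of the 3 values shown sit.

From the compounds shown here alone, whether any replacement at this position moves the number toward stronger inhibition remains open, as does the true size of this step. A longer chain, a phenyl ring or an amine in place of sec-butyl could test this position on the core of compound 1.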